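A few compounds are considered here, and "the series" means these few. Any claim that something is new, unique, unknown or untested is made for them only; others in the source may bear on it.

Measured so far:
- Compound 1, `CC(C)(N)C(=O)N[C@H](COCc1ccccc1)c1nnn(Cc2ccccc2)n1`, in a functional assay on H4 cells for agonist activity at growth hormone secretagogue receptor type 1 (Homo sapiens), read by FLIPR (on this read-out lower numbers stand for an effect already at smaller amounts and higher numbers for an effect only at larger amounts of compound), gives 1120 nM.
- Compound 2, `CC(C)(N)C(=O)N[C@H](COCc1ccccc1)c1nnn(Cc2ccccc2NS(C)(=O)=O)n1`, in this assay gives 426 nM.

Among the compounds with values here, compound 2 stands with the lowest of the two numbers, and the only step among the measured compounds is a 2.6-fold lower number from compound 1 to compound 2 (0.42 log units; beyond the scatter). Compound 3, `CC(C)(N)C(=O)N[C@H](COCc1ccccc1)c1nnn(C/C=C/c2ccccc2)n1`, differs from compound 2 by 2-phenylethenyl in place of 2-(methanesulfonamido)phenyl on a saturated chain carbon bound to an aromatic nitrogen. That change removes the methanesulfonamido group whose arrival produced the step from compound 1 to compound 2, so that step is the one that bears on it, and in reverse: the number is expected to move back toward that of compound 1. Nothing measured here speaks to the ethenyl link between the chain carbon and the ring, so that part adds only uncertainty. Compound 3 is therefore expected to show a 2.3-fold higher number from compound 2 to compound 3 (0.37 log units; beyond the scatter). The estimate for compound 3 in this assay is 1000 nM, with a range from 300 nM to 3500 nM.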

Compound 3, half-maximal effective concentration: 517 nM
For compound 3 the middle estimate is 1.9-fold (0.29 log units) above the measured one; the measured number falls inside the stated range.
By their numbers in this assay, from the lowest: compounds 2 and 3 (each within the scatter of the next); then compound 1.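

In this assay, putting 2-phenylethenyl in place of 2-(methanesulfonamido)phenyl on a saturated chain carbon bound to an aromatic nitrogen gives a 1.2-fold higher number from compound 2 to compound 3 (0.08 log units; within the scatter), so at this position a group of carbon only, with no hydrogen-bond donors or acceptors, does not separate from the one carrying methanesulfonamido. Within the data shown here, the replacement of phenyl by 2-phenylethenyl gives a 2.2-fold lower number from compound 1 to compound 3 (0.34 log units; beyond the scatter), which shows that the methanesulfonamido group is not the only change at this position that lowers the number. Nothing available accounts for either step.

The compounds shown leave open whether the double bond of 2-phenylethenyl matters, which a saturated 2-phenylethyl group would test. Also open, on these data alone, is whether an amine or a carboxylic acid on the ring of that group would shift the number further.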